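Dropping the Methyl Group: Expecting Compound 3

This account rests on a few compounds, and the source may have more. Where it says the series, first, only, none or still open, it means among the compounds named here.

Measured compounds:
- compound 1, `N#CC1=C(N)OC(c2c[nH]c3ccccc23)=C(C#N)C1c1ccc(Br)cc1`: 10.6%
- compound 2, `Cc1ccc(C2C(C#N)=C(N)OC(c3c[nH]c4ccccc34)=C2C#N)cc1`: 6.2%

Going by the values given here, in a functional assay, tested at 200 ug/mL (on this read-out higher numbers stand for a stronger effect at the one concentration tested and lower numbers for a weaker effect), compound 2 gives the lower of the two numbers measured so far, and its nearest neighbour is compound 1, whose number lies higher by an amount within the scatter. The step from compound 1 to compound 2, methyl in place of bromo on an aromatic carbon, gave a number 4.4 percentage points lower from compound 1 to compound 2 (within the scatter).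

Compound 3, `N#CC1=C(N)OC(c2c[nH]c3ccccc23)=C(C#N)C1c1ccccc1`, has not yet been measured. It differs from compound 2 by hydrogen in place of methyl on an aromatic carbon. Among the compounds with values here, the only step recorded touches the same aromatic carbon and stayed within the scatter, so there is no measured ground for expecting a shift beyond it here either; the estimate for compound 3 is therefore a step of about a number 0.8 percentage points higher from compound 2 to compound 3 (within the scatter) in this assay. Compound 3 is expected to give roughly 7%, between 1% and 17%.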

Compound 3, a percentage reported as activity, at one concentration (the size of the read-out at that concentration, not a potency): 24.5%
The estimate for compound 3 lay 17.5 percentage points below the measured number, outside the stated range (above it).
By their numbers in this assay, from the lowest: compounds 2 and 1 (each within the scatter of the next); then compound 3.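

In this assay, the position on the aromatic ring para to a large group proves sensitive after all: with nothing but hydrogen there, the read-out gives a number 18.3 percentage points higher from compound 2 to compound 3 (beyond the scatter) and also a number 13.9 percentage points higher from compound 1 to compound 3 (beyond the scatter). Compound 1 and compound 2 remain within the scatter of each other, so among these three compounds, the clear separation lies between the bare phenyl of compound 3 and the two compounds that carry a group at this position. The measurements at hand offer no explanation for this rise.

Going by these compounds, whether an amine, a carboxylic acid or a longer chain at this position would fall with methyl and bromo or reach the level of hydrogen stays open. On these data alone, each number also comes from a single concentration, so how the compounds compare in potency is unknown.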